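Swapping the pyridin-2-yl arm of compound 1 for fluorophenyl

A few compounds are considered here, and "the series" means these few. Any claim that something is new, unique, unknown or untested is made for them only; others in the source may bear on it.

Compound 1 `CC(Sc1nc2c(cnn2C)c(=O)n1-c1ccccc1)c1ccccn1` gives 89 nM in an assay on isolated protein for inhibition of Retinaldehyde dehydrogenase 3 (Homo sapiens); a lower number here means a stronger inhibitor, a higher number a weaker inhibitor. Compound 2 `CC(Sc1nc2nn(C3COC3)cc2c(=O)n1-c1ccccc1)c1ccccc1` gives 109 nM and compound 3 `CC(Sc1nc2nn(C3(C)COC3)cc2c(=O)n1-c1ccccc1)c1ccccc1` gives 50 nM in this assay. The three numbers lie close together: compound 1 stands within the usual scatter of both compound 2 and compound 3, so no order among them can be read. Among the compounds with values here, the only step measured within the set, a 2.2-fold lower number from compound 2 to compound 3 (0.34 log units; beyond the scatter), concerns a methyl in place of hydrogen on a saturated ring carbon and touches a different part of the molecule from the change now considered.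

Compound 4 `CC(Sc1nc2c(cnn2C)c(=O)n1-c1ccccc1)c1cccc(F)c1` differs from compound 1 by 3-fluorophenyl in place of pyridin-2-yl on a saturated chain carbon bound to a saturated chain carbon and a sulfur. Within the data shown here, no measured step bears on this change. Compound 2 and compound 3 carry a phenyl in place of the pyridin-2-yl, but on a different core, and their numbers sit within the scatter of compound 1, which gives no direction. The step of a 1.1-fold higher number from compound 1 to compound 4 (0.05 log units; within the scatter) is therefore expected to stay within the scatter, with neither direction favoured. Compound 4 is estimated at 100 nM, between 40 nM and 250 nM.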

Compound 4, half-maximal inhibitory concentration: 128 nM
Estimate against measurement, compound 4: 1.3-fold (0.11 log units) below, and the stated range covers the measured number.
By their numbers in this assay, from the lowest: compounds 3, 1, 2 and 4 (each within the scatter of the next, the first and the last beyond it).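

On the saturated chain carbon bound to a saturated chain carbon and a sulfur, in this assay, 3-fluorophenyl in place of pyridin-2-yl gives a 1.4-fold higher number from compound 1 to compound 4 (0.16 log units; within the scatter), so the two arms cannot be told apart on the core of compound 1. The hydrogen-bond acceptor counted on pyridin-2-yl is absent from 3-fluorophenyl, and for this pair that difference leaves no readable trace in the number. No measurement on hand explains this step.

The entry of the fluorine and the loss of the ring nitrogen stay tied together in this single step, so neither can be read alone. Also open, from the compounds shown here alone, is whether this position accepts a group of another kind, such as a carboxylic acid on the ring or an aliphatic amine in place of the ring.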